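The source may report more compounds than this note shows. Statements on the series, on what has been measured and on what is new or still open speak of the compounds shown alone.

Compound 1, `O=C(CCCCC1CCSS1)NCc1cn(CCCOc2ccc3cc(-c4ccccc4)c(=O)oc3c2)nn1`, is the starting point of this small series. In a functional assay on PC-12 cells (Rattus norvegicus) for cytotoxicity, read by MTT assay, with stated times of 3 h and 2 h, tested at 0.1 uM (a lower number here means a weaker effect, a higher number a stronger effect of the compound at the concentration tested), compound 1 gives 33.9%. Compound 2, `O=C(CCCCC1CCSS1)NCc1cn(CCCOc2ccc3cc(-c4ccc(Cl)cc4)c(=O)oc3c2)nn1`, carries one change relative to compound 1: chloro in place of hydrogen on an aromatic carbon. In this assay compound 2 gives 40.9%, and the step of a number 7 percentage points higher from compound 1 to compound 2 (within the scatter) was recorded. Compound 3, `O=C(CCCCC1CCSS1)NCc1cn(CCCCOc2ccc3cc(-c4ccc(Cl)cc4)c(=O)oc3c2)nn1`, is built on a core that differs from that of compound 1; the difference between the two cores is not broken down here. In this assay, among the measured compounds shown here, compound 3 gives 38.8%, a number that lies close to the one of compound 2 and likewise close to the one of compound 1.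

Compound 4, `O=C(CCCCC1CCSS1)NCc1cn(CCCCOc2ccc3cc(-c4ccc(Cl)c(Cl)c4)c(=O)oc3c2)nn1`, has not yet been measured. It differs from compound 3 by chloro in place of hydrogen on an aromatic carbon. For the measured compounds named here, this is the same kind of change as the one from compound 1 to compound 2, but the place is not the same: in compound 2 the entering chloro stands para to a large group, whereas in compound 4 it stands ortho to a chloro group and meta to a large group. Going by the values given here, the expectation for compound 4 rests on the single earlier example of this change, the step of a number 7 percentage points higher from compound 1 to compound 2 (within the scatter). For compound 4 a step of similar size is expected, a number 5.2 percentage points higher from compound 3 to compound 4 (within the scatter). Compound 4 is therefore estimated to give 44% in this assay, with the likely range running from 32% to 56%.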

Compound 4, a percentage reported as activity, at one concentration (the size of the read-out at that concentration, not a potency): 39.6%
Estimate against measurement, compound 4: 4.4 percentage points above; the range from low to high includes it.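

In this assay the second chloro gives a number 0.8 percentage points higher from compound 3 to compound 4 (within the scatter), and set beside the first case of this change, a number 7 percentage points higher from compound 1 to compound 2 (within the scatter), the two steps cannot be told apart: the same change on two cores in this assay, a number 7 percentage points higher (within the scatter) from compound 1 to compound 2 and a number 0.8 percentage points higher (within the scatter) from compound 3 to compound 4, 6.2 percentage points apart, within the scatter of two such steps. This shows that the change reads alike on the two cores as far as this small set can tell, since neither step stands clear of the scatter and the gap between them does not either. Among the compounds shown here, it does not show that chloro in place of hydrogen has a real effect on either core, nor that a step of fixed size carries from one core to another, as the evidence is only two pairs, the entering chloro does not stand at the same place in them, and each read-out comes from a single concentration and is not a potency.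

The compounds shown leave open whether a fluoro, methoxy or nitrile group in place of the chloro, or a longer chain in the linker, would move the number beyond the scatter. They also leave open how the 3,4-dichlorophenyl group would read on the core of compound 1, and whether any of these compounds would differ at other concentrations.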